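Thiazole carboxamide series: fluoro for bromo on the indolyl ring

This account rests on a few compounds, and the source may have more. Where it says the series, first, only, none or still open, it means among the compounds named here.

Measured in a functional assay on LNCaP C4-2 cells (Homo sapiens) for cytotoxicity, read by MTT assay, with a stated time of 48 h, in the absence of a further agent; on this read-out lower numbers stand for stronger inhibition and higher numbers for weaker inhibition:
compound 1 `COc1ccc2[nH]cc(-c3nc(C(=O)Nc4cc(OC)c(OC)c(OC)c4)cs3)c2c1` gives > 100000 nM, a limit of the assay.
compound 2 `COc1cc(NC(=O)c2csc(-c3c[nH]c4ccc(Br)cc34)n2)cc(OC)c1OC` gives > 100000 nM, again a limit.

Compound 2 thus stands at the limit, which is where both shown values sit (the limit of > 100000 nM in this assay, at which 2 of the 2 values shown sit). Among the measured compounds shown here, the single step from compound 1 to compound 2 reads a step that the two limits leave unreadable from compound 1 to compound 2 and gives no size.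

Compound 3 `COc1cc(NC(=O)c2csc(-c3c[nH]c4ccc(F)cc34)n2)cc(OC)c1OC` differs from compound 2 by fluoro in place of bromo on an aromatic carbon. No readable step bears on this change, so no step beyond the scatter is expected in this assay; the estimate is that compound 3 gives 100000 nM (range 30000 nM to 300000 nM), a limit once more being the most likely outcome. The expected step is a number no higher from compound 2 to compound 3 (the limit leaves the size open).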

Compound 3, half-maximal inhibitory concentration: > 100000 nM
Compound 3: only a limit was reported (the forecaster's own chance of this, stated with the estimate: 80%); the middle value sits exactly at the limit.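

Among the compounds shown here, compound 1, compound 2 and compound 3 all sit at a limit of the assay, so no step among them can be read. The compounds shown leave open whether methoxy, bromo or fluoro at this place makes any difference to cytotoxicity.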